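The source may report more compounds than this note shows. Statements on the series, on what has been measured and on what is new or still open speak of the compounds shown alone.

Of the compounds shown here, three sharing one core have been tested in a functional assay on HL-60 cells (Homo sapiens) for cytotoxicity, read by MTT assay, with a stated time of 48 h; a higher number here means a weaker inhibitor, a lower number a stronger inhibitor. In this test, compound 1 `Fc1cccc(-c2nc(Nc3ccc(Cl)cc3)c3cc(F)ccc3n2)c1` gives 45700 nM. Compound 2 `Fc1cccc(-c2nc(Nc3cccc(Cl)c3)c3cc(F)ccc3n2)c1` reaches only a limit of the assay, > 50000 nM. Compound 3 `Oc1ccccc1Nc1nc(-c2cccc(F)c2)nc2ccc(F)cc12` gives 44400 nM. That places compound 3 level with compound 1, the measured change being a 1.0-fold lower number from compound 1 to compound 3 (0.01 log units; within the scatter). Against the limit of compound 2, the comparison gives only an at least 1.1-fold lower number from compound 2 to compound 3 (0.05 log units; that floor lies within the scatter).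

Compound 4 `Cc1cccc(Nc2nc(-c3cccc(F)c3)nc3ccc(F)cc23)c1` has 3-methylphenyl in place of 2-hydroxyphenyl on a nitrogen on an aromatic ring. This compound has not yet been measured.

The closest guidance comes from the other exchanges on that same nitrogen. Besides the two steps above, there is an at least 1.0-fold higher number from compound 1 to compound 2 (0.03 log units; that floor lies within the scatter). None of the three moves beyond the scatter, so the groups tried at this nitrogen have not yet separated in this assay. The limit also has to be reckoned with: the limit of > 50000 nM in this assay, at which 1 of the 3 values shown sits.

No step beyond the scatter is therefore expected in either direction. The expected change is a 1.1-fold higher number from compound 3 to compound 4 (0.03 log units; within the scatter). For compound 4 the estimated value is 48000 nM, with an expected range from 24000 nM to 95000 nM, and the assay may report only its limit.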

Compound 4, half-maximal inhibitory concentration: > 50000 nM
Compound 4 gave a limit, no number; the forecaster's own chance of this, stated with the estimate: 45%; middle value at least 1.0-fold (0.01 log units) away from the limit.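

Going by these compounds alone, with compound 4, the exchange on this nitrogen has for the first time removed the hydrogen-bond donor and acceptor counted for 2-hydroxyphenyl, leaving a group with neither, and this assay still shows no step that can be placed beyond the scatter: an at least 1.1-fold higher number from compound 3 to compound 4 (0.05 log units; that floor lies within the scatter), and an at least 1.0-fold higher number from compound 1 to compound 4 (0.03 log units; that floor lies within the scatter). The step between compound 2 and compound 4, methyl in place of chloro on an aromatic carbon, cannot be read, as both compounds give only a limit of the assay. A second group among the meta-free names tried here, 3-methylphenyl after the 3-chlorophenyl of compound 2, thus ends at the same limit, so only compound 1 and compound 3 still give numbers in this test: the limit of > 50000 nM in this assay, at which 2 of the 4 values shown sit.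

On these data alone, what stays open is whether any group on this nitrogen can give a number clearly lower than those of compound 1 and compound 3, for instance a phenyl ring carrying an amine or a carboxylic acid, or a longer chain in place of the ring. The compounds shown also leave apart whether the hydroxyl itself or its place on the ring counts, since 2-hydroxyphenyl and 3-methylphenyl differ in both.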